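Replacing the amino acid arm with a dimethylaminoethyl amine

The source may hold more compounds than are shown below. What is called first, only, known or untested is meant among the compounds shown, and "the series" means these compounds.

Measured compounds:
compound 1, `COc1ccc(/C=C\c2cc(OC)c(OC)c(OC)c2)cc1OCc1ccc(CN[C@H](C(=O)O)[C@H](C)O)cc1`, in a functional assay on HeLa cells (Homo sapiens) for antiproliferative activity, read by CCK-8 assay, with a stated time of 48 h; a higher number here means a weaker inhibitor, a lower number a stronger inhibitor: > 10000 nM
compound 2, `COc1ccc(/C=C\c2cc(OC)c(OC)c(OC)c2)cc1OCc1ccc(CN2C[C@H](O)C[C@@H]2C(=O)O)cc1`: > 10000 nM
compound 3, `COc1ccc(/C=C\c2cc(OC)c(OC)c(OC)c2)cc1OCc1ccc(CN[C@H](C(=O)O)[C@@H](C)O)cc1`: > 10000 nM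

Compound 3 stands at a limit of this assay, not at a number. Compound 1 likewise reaches only a limit in this assay. Compound 2 also gives only a limit in this assay. All three therefore sit at the limit of > 10000 nM in this assay, at which 3 of the 3 values shown sit, so the steps a step that the two limits leave unreadable from compound 1 to compound 2, a step that the two limits leave unreadable from compound 1 to compound 3 and a step that the two limits leave unreadable from compound 2 to compound 3 cannot be read in size, even though the fact that compounds 1 and 3 differ only in the configuration as drawn makes the pair of compound 1 and compound 3 the closest comparison present.

Compound 4, `COc1ccc(/C=C\c2cc(OC)c(OC)c(OC)c2)cc1OCc1ccc(CNCCN(C)C)cc1`, carries 2-(dimethylamino)ethyl in place of 1-carboxy-2-hydroxypropyl on an amine nitrogen. Within the data shown here, none of the measured steps changes the amine substituent in this way, and none yields a readable size, so they offer no guide to the direction or size of the step to compound 4 in this assay.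

Among the measured compounds shown here, with no informative step, compound 4 is estimated at 2000 nM, within 100 nM to 20000 nM, which would mean an expected step of an at least 5.0-fold lower number from compound 3 to compound 4 (0.69 log units; beyond the scatter), though a further limit is also plausible.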

Compound 4, half-maximal inhibitory concentration: 9400 nM
Compound 4: middle estimate off by 4.7-fold (0.67 log units), on the low side; the measured number falls inside the stated range.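

In this assay compound 4, with 2-(dimethylamino)ethyl in place of 1-carboxy-2-hydroxypropyl on the amine nitrogen, gives 9400 nM, the first number rather than a limit at this position. Compound 1, compound 2 and compound 3 each stay at a limit: the limit of > 10000 nM in this assay, at which 3 of the 4 values shown sit.

The change therefore reads only as an at least 1.0-fold lower number from compound 3 to compound 4 (0.02 log units; that floor lies within the scatter), as an at least 1.0-fold lower number from compound 2 to compound 4 (0.02 log units; that floor lies within the scatter) and as an at least 1.0-fold lower number from compound 1 to compound 4 (0.02 log units; that floor lies within the scatter), and these floors establish no change beyond the scatter, nor do they say how large the true steps are.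

From the compounds shown here alone, it remains open whether the loss of the carboxylic acid or the arrival of the dimethylamino group accounts for the number seen with compound 4. Going by these compounds, what a longer chain ending in dimethylamino, or a morpholine on that chain, would give in this assay is also open.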